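The source may hold more compounds than are shown below. What is called first, only, known or untested is meant among the compounds shown, and "the series" means these compounds.

In a functional assay on SGC-7901 cells (Homo sapiens) for antiproliferative activity, read by MTT assay, with a stated time of 48 h (on this read-out lower numbers stand for an effect already at smaller amounts and higher numbers for an effect only at larger amounts of compound), compound 1 `CC1=NN(C(=O)C(F)(F)F)C(c2ccccc2O)C1` gives 2060 nM. Compound 2 `CC1=NN(S(=O)(=O)c2ccc(F)cc2)C(c2cc(Br)ccc2O)C1` gives no exact number, and its > 60000 nM is a limit of the assay. Compound 3 `CC1=NN(S(=O)(=O)c2ccc(Cl)cc2Cl)C(c2cc(Br)ccc2O)C1` also reaches only a limit, > 60000 nM. Compound 2 therefore stands at the limit of > 60000 nM in this assay, at which 2 of the 3 values shown sit.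

Compound 4 `CC1=NN(S(=O)(=O)c2ccc(C(F)(F)F)cc2)C(c2cc(Br)ccc2O)C1` differs from compound 2 in one place, with trifluoromethyl in place of fluoro on an aromatic carbon, para to a large group: trifluoromethyl in place of fluoro on an aromatic carbon. Among the compounds with values here, the only measured step that bears on this change is a step that the two limits leave unreadable from compound 2 to compound 3. That step also alters the group on the sulfonyl sulfur, but it provides no size to carry over. With so little to go on, no step beyond the usual scatter is expected, and another limit is the likeliest report. The expected change is a number no higher from compound 2 to compound 4 (the limit leaves the size open). For compound 4 the estimated value is 60000 nM, with an expected range from 20000 nM to 120000 nM.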

Compound 4, half-maximal effective concentration: 16300 nM
Estimate against measurement, compound 4: 3.7-fold (0.57 log units) above; measured number below the stated range.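

In this assay, trifluoromethyl in place of fluoro on this aromatic carbon, para to a large group, gives an at least 3.6-fold lower number from compound 2 to compound 4 (0.56 log units; beyond the scatter). Compound 4 is the first of the sulfonyl compounds shown to give an exact number, so this position can shift the read-out, which the earlier compounds could not show. The size of the step remains only a minimum because compound 2 gives a limit and not a number: the limit of > 60000 nM in this assay, at which 2 of the 4 values shown sit.

Going by these compounds, how a nitrile, a methoxy group or an amine on this same aromatic carbon would read remains open. On these data alone, compound 1 differs from compound 4 in more than one place, so the effect of swapping the sulfonyl group for the trifluoroacetyl group of compound 1 also remains open.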